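This account rests on a few compounds, and the source may have more. Where it says the series, first, only, none or still open, it means among the compounds named here.

Three related compounds have been measured in a functional assay on MV4-11 cells (Homo sapiens) for inhibition, read by resazurin assay, with a stated time of 72 h; a lower number here means a stronger inhibitor of growth, a higher number a weaker inhibitor of growth. Compound 1 (`CCn1cc(-c2ccnc(Nc3ccc(OC)cc3OC)n2)c2ccccc21`) gives 3590 nM, compound 2 (`COCCOc1nc(C)c(-c2ccnc(Nc3ccc(OC)cc3OC)n2)s1`) gives 1980 nM, and compound 3 (`COc1ccc(Nc2nccc(-c3sc(OC)nc3C)n2)c(OC)c1`) gives 1400 nM. Compound 1 thus lies within the scatter of compound 2, while the gap between compound 1 and compound 3 lies beyond it.

Compound 4 (`CCCn1cc(-c2ccnc(Nc3ccc(OC)cc3OC)n2)c2ccccc21`) departs from compound 1 in a single place: methyl in place of hydrogen on a saturated chain carbon, two bonds along the chain from an aromatic nitrogen. In words, this is methyl in place of hydrogen on a saturated chain carbon, two bonds along the chain from an aromatic nitrogen, so that ethyl becomes propyl. For the measured compounds named here, no measured step shows this exact change. The nearest evidence is a 1.4-fold lower number from compound 2 to compound 3 (0.15 log units; within the scatter), a change on a chain bound through oxygen on a different core, so it bears only loosely. It gives no reason to expect a shift beyond the scatter in either direction. The expected step is a 1.1-fold lower number from compound 1 to compound 4 (0.02 log units; within the scatter), which would stay within the scatter. Compound 4 is estimated at 3400 nM, with an expected range of 1600 nM to 7000 nM.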

Compound 4, concentration for 50% growth inhibition: 3620 nM
The estimate for compound 4 lay 1.1-fold (0.03 log units) below the measured number; measured number inside the range.
By their numbers in this assay, from the lowest: compounds 3, 2, 1 and 4 (each within the scatter of the next, the first and the last beyond it).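

Methyl in place of hydrogen on a saturated chain carbon, two bonds along the chain from an aromatic nitrogen, makes ethyl into propyl, and in this assay this gives a 1.0-fold higher number from compound 1 to compound 4 (0.00 log units; within the scatter). For the compounds shown here, this is the first direct reading at this position, since the earlier compounds carried only ethyl there and their one step lay on a chain bound through oxygen on a different core. On the core of compound 1, the position thus takes the added methyl with no shift beyond the scatter, and no measured evidence speaks to why.

The compounds shown leave open whether a longer chain such as butyl, or a chain ending in an amine or a carboxylic acid, would read the same at this position. They also leave open whether ethyl and propyl would read alike on the core of compound 2.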